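Trimming 3-hydroxypropyl to ethyl on compound 1

The compounds below may be only part of what the source reports. "The series", "measured", "known", "first", "only" and "open" are said of these compounds alone.

For the measured compounds named here, in a functional assay on RCC4 cells (Homo sapiens) for inhibition, read by XTT assay, with a stated time of 4 days (a lower number here means a stronger inhibitor, a higher number a weaker inhibitor), compound 1 (`Cc1cccc(Nc2nc(-c3ccnc(CCCO)c3)cs2)c1`) gives 5250 nM, its only single number, and one further entry for it carries no single number. In this assay, compound 2 (`Cc1cccc(Nc2nc(-c3ccnc(-c4cccc5[nH]ccc45)c3)cs2)c1`) gives 3100 nM; 3160 nM (2 entries), and its repeat entries agree closely (the several entries of compound 2 in this assay, 3100 nM; 3160 nM (2 entries)). The values of the two compounds lie within the usual scatter of each other.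

Compound 3 (`CCc1cc(-c2csc(Nc3cccc(C)c3)n2)ccn1`) has not yet been measured. It carries hydrogen in place of hydroxymethyl on a saturated chain carbon, two bonds along the chain from an aromatic carbon, which turns 3-hydroxypropyl into ethyl (hydrogen in place of hydroxymethyl on a saturated chain carbon, two bonds along the chain from an aromatic carbon). Going by the values given here, no measured step speaks to this change, so the expectation rests on compound 1 at 5250 nM, with no shift beyond the scatter in this assay. The expected step is a 1.3-fold lower number from compound 1 to compound 3 (0.12 log units; within the scatter). For compound 3 the estimated value is 4000 nM, with an expected range of 1500 nM to 10000 nM.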

Compound 3, half-maximal inhibitory concentration: 6460 nM
Compound 3: the middle estimate sits 1.6-fold (0.21 log units) below what was measured, within the range that was stated.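

Trimming 3-hydroxypropyl to ethyl gives a 1.2-fold higher number from compound 1 to compound 3 (0.09 log units; within the scatter) in this assay. For the compounds shown here, this is the first measured step at this place, and it shows that hydroxymethyl can give way to hydrogen on this saturated chain carbon without a shift beyond the scatter, so the end of this chain does not set the reading here. Repeat readings in this assay can agree closely, which gives this flat step some footing: the several entries of compound 2 in this assay, 3100 nM; 3160 nM (2 entries).

From the compounds shown here alone, whether the flat reading holds for other groups stays open, as an amine or a carboxylic acid at the end of the chain, or a longer chain, might read differently. A single step on one pair also cannot say why the change leaves the reading in place, or whether it would do so on another core.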